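From Dimethylamino to Vinyl: One Change, One Estimate

The source may hold more compounds than are shown below. What is called first, only, known or untested is meant among the compounds shown, and "the series" means these compounds.

Of the compounds shown here, three of this set have been tested in a functional assay on HCT-116 cells (Homo sapiens) for inhibition, read by CCK-8 assay, with a stated time of 48 h; on this read-out higher numbers stand for weaker inhibition and lower numbers for stronger inhibition. Compound 1, `COc1cc(-c2ccnc3c(-c4ccc(C)cc4)cnn23)cc(OC)c1OC`, gives only a limit of the assay, > 10000 nM. Compound 2, `COc1ccc(-c2cc3nccc(-c4cc(OC)c(OC)c(OC)c4)n3n2)cc1[N+](=O)[O-]`, likewise gives only a limit, > 10000 nM. Going by the values given here, compound 3, `COc1cc(-c2ccnc3cc(-c4ccc(N(C)C)cc4)nn23)cc(OC)c1OC`, is the one compound with a number: in this assay compound 3 gives 2050 nM. Among the compounds with values here, two of the three results sit at the limit of > 10000 nM in this assay, at which 2 of the 3 values shown sit, so compound 3 stands alone as the only measured value in this set.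

Compound 4, `C=Cc1ccc(-c2cc3nccc(-c4cc(OC)c(OC)c(OC)c4)n3n2)cc1`, has not yet been measured. It differs from compound 3 in one place: vinyl in place of dimethylamino on an aromatic carbon. Within the data shown here, no pair of measured compounds shows a step in this assay that would guide this change, so the size of the step can only be estimated. A small loss is expected, and the step is estimated at a 2.0-fold higher number from compound 3 to compound 4 (0.29 log units; within the scatter), roughly at the edge of the usual scatter. Compound 4 is therefore expected to give about 4000 nM in this assay, with a range from 1500 nM to 12000 nM.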

Compound 4, half-maximal inhibitory concentration: 1060 nM
For compound 4 the middle estimate is 3.8-fold (0.58 log units) above the measured one; measured number outside the range, below it.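

In this assay the swap to vinyl gives a 1.9-fold lower number from compound 3 to compound 4 (0.29 log units; within the scatter) and so, in this pair, the two groups cannot be told apart at this place on the aromatic ring. Going by these compounds alone, this is the first direct one-place comparison in the set, and it shows that the nitrogen and the hydrogen-bond acceptor of dimethylamino can leave without the number moving beyond the usual scatter. Nothing measured here bears on why the two groups read alike.

Going by these compounds, how a carboxylic acid or a longer carbon chain would read at this same place remains open. Compound 1 and compound 2 differ from this pair in more than one place, and the set holds few true numbers to extend the comparison: the limit of > 10000 nM in this assay, at which 2 of the 4 values shown sit.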